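Working notes: cytotoxicity expectation for compound 4

The source may report more compounds than this note shows. Statements on the series, on what has been measured and on what is new or still open speak of the compounds shown alone.

Measured so far:
compound 1, `O=C(CN1CCCCC1)Nc1ccc(-c2nc3cc(Cl)c(Cl)cc3[nH]2)cc1`, > 100000 nM
compound 2, `Fc1cccc(F)c1-c1nc2cc(Cl)c(Cl)cc2[nH]1`, > 100000 nM
compound 3, `CCC(=O)Nc1ccc(-c2nc3cc(C(F)(F)F)ccc3[nH]2)cc1`, > 100000 nM

In an ADME assay on Vero cells (Chlorocebus sabaeus) for cytotoxicity (on this read-out lower numbers stand for higher toxicity in this test and higher numbers for lower toxicity in this test), compound 1 gives > 100000 nM, which is a limit of the assay and not a number. Compound 2 also reaches only a limit in this assay, > 100000 nM. Compound 3 likewise sits at a limit in this assay, > 100000 nM. Every value shown rests at the limit of > 100000 nM in this assay, at which 3 of the 3 values shown sit, so compound 1 stands where the other two stand, with no number to set it against. Compound 4, `CC(=O)Nc1ccc(-c2nc3cc(Cl)c(Cl)cc3[nH]2)cc1`, has not been measured in this assay. It differs from compound 1 by hydrogen in place of piperidin-1-yl on a saturated chain carbon bound to a carbonyl carbon. Within the data shown here, no step between measured compounds is available, and none of the three values shown separates from the others. The change is therefore expected to stay within the scatter, a step that the limit leaves unreadable from compound 1 to compound 4. Compound 4 is expected to give 150000 nM in this assay, within a range from 60000 nM to 400000 nM, most likely again only as a limit.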

Compound 4, half-maximal cytotoxic concentration: > 100000 nM
Compound 4: only a limit was reported; the forecaster's own chance of this, stated with the estimate: 85%; the middle value does not contradict the limit.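

No step can be read from compound 1 to compound 4 in this assay, since both results are limits and not numbers: the limit of > 100000 nM in this assay, at which 4 of the 4 values shown sit.

The compounds shown leave open whether hydrogen in place of piperidin-1-yl changes this read-out at all, and how any of these compounds ranks against the others.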